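This account rests on a few compounds, and the source may have more. Where it says the series, first, only, none or still open, it means among the compounds named here.

Measured so far:
compound 1, `Oc1cccc(-c2cc(-c3ccsc3)cc(-c3ccccc3O)n2)c1`: > 50000 nM
compound 2, `Oc1ccccc1-c1cc(-c2ccco2)cc(-c2ccccc2O)n1`: > 50000 nM

Both results come from a functional assay on DU-145 cells (Homo sapiens) for cytotoxicity, read by CCK-8 assay; on this read-out higher numbers stand for weaker inhibition and lower numbers for stronger inhibition. For compound 1 the result > 50000 nM is a limit of the assay, not a number. For compound 2 the result > 50000 nM is likewise a limit, so compound 2 stands at the edge of what this assay can report rather than at a measured point. Going by the values given here, the only thing the two results show together is the limit of > 50000 nM in this assay, at which 2 of the 2 values shown sit, and no step between two measured compounds can be worked out from them.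

Compound 3, `Oc1cccc(-c2cc(-c3ccco3)cc(-c3ccccc3O)n2)c1`, has the same atoms as compound 2, joined differently: 3-hydroxyphenyl in place of 2-hydroxyphenyl on an aromatic carbon. Among the compounds with values here, with both measured compounds sitting at the limit, no measured step guides what this change should do, so the expected step from compound 2 to compound 3 in this assay is a step that the limit leaves unreadable from compound 2 to compound 3, that is, none beyond the scatter. Compound 3 is therefore estimated at 60000 nM, with a range from 15000 nM to 250000 nM, and most likely the assay will again report only a limit.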

Compound 3, half-maximal inhibitory concentration: 1790 nM
Estimate against measurement, compound 3: 34-fold (1.53 log units) above; the whole stated range lies above it.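

In this assay, going by these compounds alone, the position next to the ring nitrogen proves sensitive to where the hydroxyl group sits on its phenyl ring, which the earlier compounds could not show. With the furan-2-yl group kept in place, 3-hydroxyphenyl in place of 2-hydroxyphenyl gives an at least 27-fold lower number from compound 2 to compound 3 (1.44 log units; beyond the scatter), so two groups with the same atoms are clearly told apart by the cells. The 3-hydroxyphenyl group is not enough by itself, however: compound 1 carries it too and stays at a limit, while furan-2-yl in place of thiophen-3-yl gives an at least 27-fold lower number from compound 1 to compound 3 (1.44 log units; beyond the scatter), so the measurable activity of compound 3 depends on both of these groups, and the true size of either step cannot be read, since each starts from a limit rather than a number: the limit of > 50000 nM in this assay, at which 2 of the 3 values shown sit.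

The compounds shown leave open whether the hydroxyl group itself matters or only its place on the ring, which a methoxy group or an amine at the same spot on the phenyl ring would help to settle. They also leave open whether the 2-hydroxyphenyl group that all three compounds keep can be changed without losing this activity.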